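Adding methylcarbamoyl to compound 1: clearance outlook

The source may report more compounds than this note shows. Statements on the series, on what has been measured and on what is new or still open speak of the compounds shown alone.

Going by the values given here, compound 1 `Cc1ncccc1-c1cnc(NCc2c(F)ccc3c2CCO3)c2cn[nH]c(=O)c12` offers no anchor for this step. In an ADME assay on the whole organism (Rattus norvegicus) for pharmacokinetics (on this read-out lower numbers stand for slow clearance and higher numbers for fast clearance), compound 1 has the entry "not determined" (no result reported) and so gives no number to start from. The nearest measured reference is compound 2 `CN(c1ccn(C)n1)c1cnc(NCc2c(F)ccc3c2CCO3)n2cnnc12`, which differs from compound 1 in more than one place. In this assay, among the compounds with values here, compound 2 gives 29 mL/min/kg and is the only number so far.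

Compound 3 `CNC(=O)c1ccc(-c2cnc(NCc3c(F)ccc4c3CCO4)c3cn[nH]c(=O)c23)c(C)n1` keeps the core of compound 1 and carries methylcarbamoyl in place of hydrogen on an aromatic carbon. The new group sits next to the ring nitrogen, meta to a methyl group, and the 2-methylpyridin-3-yl becomes 2-methyl-6-(methylcarbamoyl)pyridin-3-yl (methylcarbamoyl in place of hydrogen on an aromatic carbon).

Within the data shown here, no measured pair shows what this change does in this assay, so the size of the step cannot be read from the data. A small move towards slower clearance is expected, with no firm claim that it would exceed the scatter. The estimate therefore leans on compound 2 (29 mL/min/kg) and stays wide. Compound 3 is expected at 20 mL/min/kg (estimated range 8 mL/min/kg to 45 mL/min/kg).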

Compound 3, clearance: 24 mL/min/kg
Estimate against measurement, compound 3: 1.2-fold (0.08 log units) below, within the range that was stated.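

No step can be read between compound 1 and compound 3: in this assay only compound 3 at 24 mL/min/kg carries a number here. Going by these compounds, what methylcarbamoyl in place of hydrogen does to clearance on the core of compound 1 stays open. No evidence bearing on this result is available.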